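A few compounds are considered here, and "the series" means these few. Any claim that something is new, unique, unknown or untested is made for them only; others in the source may bear on it.

Working notes on the series, all read in a physicochemical assay for solubility, measured as kinetic solubility, at pH 2; on this read-out higher numbers stand for higher solubility and lower numbers for lower solubility. Compound 1 (`CC(C)C(Cc1noc(=O)[nH]1)c1ccc(-c2ccc3cccc(F)c3c2)[nH]c1=O`) gives 18200 nM, compound 2 (`CC(C)C(c1ncc[nH]1)c1ccc(-c2ccc3cccc(F)c3c2)[nH]c1=O`) gives 31800 nM and compound 3 (`CC(C)C(Cc1nnn[nH]1)c1ccc(-c2ccc3cccc(F)c3c2)[nH]c1=O`) gives 28000 nM. Compound 3 therefore stands within the scatter of both others, as do the other two of each other: a 1.5-fold higher number from compound 1 to compound 3 (0.19 log units; within the scatter), a 1.1-fold lower number from compound 2 to compound 3 (0.06 log units; within the scatter) and a 1.7-fold higher number from compound 1 to compound 2 (0.24 log units; within the scatter).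

The next structure is compound 4 (`CC(C)C(/C=C1\CCNC1=O)c1ccc(-c2ccc3cccc(F)c3c2)[nH]c1=O`), with this change: a group of 7 heavy atoms (5 carbon, 1 nitrogen, 1 oxygen; one five-membered non-aromatic ring with 1 hetero atom) in place of a group of 6 heavy atoms (2 carbon, 4 nitrogen; one five-membered aromatic ring with 4 hetero atoms), on a saturated chain carbon bound to an aromatic carbon and a saturated chain carbon. The measured steps all exchange one five-membered aromatic ring for another, so none tests the one five-membered non-aromatic ring directly. Going by the values given here, they are the only guide, and each stays small, as in a 1.1-fold lower number from compound 2 to compound 3 (0.06 log units; within the scatter). No step beyond the scatter is therefore expected, and the estimate is a 1.1-fold lower number from compound 3 to compound 4 (0.05 log units; within the scatter). Compound 4 is estimated at 25000 nM, with an expected range of 10000 nM to 60000 nM.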

Compound 4, solubility: 23600 nM
For compound 4 the middle estimate is 1.1-fold (0.03 log units) above the measured one, and the stated range covers the measured number.
By their numbers in this assay, from the lowest: compounds 1, 4, 3 and 2 (each within the scatter of the next).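

At this place, on a saturated chain carbon bound to an aromatic carbon and a saturated chain carbon, the one five-membered non-aromatic ring in the series stays within the scatter of all three aromatic-ring groups in this assay (a 1.2-fold lower number from compound 3 to compound 4 (0.07 log units; within the scatter); a 1.3-fold lower number from compound 2 to compound 4 (0.13 log units; within the scatter); a 1.3-fold higher number from compound 1 to compound 4 (0.11 log units; within the scatter)). Exchanging an aromatic ring for this non-aromatic one therefore gives no readable step among these compounds. No supporting measurement bears on why. Still open, from the compounds shown here alone, is whether a carboxylic acid or an amine at this place would give a step beyond the scatter.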